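The source may report more compounds than this note shows. Statements on the series, on what has been measured and on what is new or still open speak of the compounds shown alone.

In a functional assay on PC-3 cells (Homo sapiens) for inhibition, read by MTT assay, with a stated time of 48 h, tested at 10 uM (on this read-out lower numbers stand for less inhibition of growth and higher numbers for more inhibition of growth at the one concentration tested), three compounds sharing one core and differing only in one aromatic group have been measured. Compound 1 `Cc1oc2c([C@H]3CCN(C)C[C@H]3O)c(O)cc(O)c2c(=O)c1C(O)c1ccc([N+](=O)[O-])cc1` gives 24%, and compound 2 `Cc1oc2c([C@H]3CCN(C)C[C@H]3O)c(O)cc(O)c2c(=O)c1C(O)c1ccccc1Br` gives 45%. Compound 3 `Cc1oc2c([C@H]3CCN(C)C[C@H]3O)c(O)cc(O)c2c(=O)c1C(O)c1cc(F)cc(F)c1` gives 0%, the lowest of the three numbers. Compound 4 `Cc1oc2c([C@H]3CCN(C)C[C@H]3O)c(O)cc(O)c2c(=O)c1C(O)c1ccc(F)cc1` has not yet been measured. Its change from compound 3 is 4-fluorophenyl in place of 3,5-difluorophenyl on a saturated chain carbon bound to an aromatic carbon and an oxygen on a saturated carbon.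

All three measured steps were made at this same place, and all lie beyond the scatter. The modest ones are a number 21 percentage points higher from compound 1 to compound 2 (beyond the scatter) and a number 24 percentage points lower from compound 1 to compound 3 (beyond the scatter), while the large one is a number 45 percentage points lower from compound 2 to compound 3 (beyond the scatter). Among the measured compounds shown here, the read-out therefore responds to this group, but no measured step removes a single fluorine, so the evidence is indirect. Compound 3 stands at 0%, which leaves little room for any further drop, and compound 1, which also carries a 4-substituted phenyl, stands at 24%. A modest rise is therefore the expectation, though one that may stay close to the scatter. The expected step is a number 16 percentage points higher from compound 3 to compound 4 (beyond the scatter). The estimate for compound 4 is 16%, with an expected range of 0% to 38%.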

Compound 4, percent growth inhibition at one concentration: 0%
Compound 4: middle estimate off by 16 percentage points, on the high side, within the range that was stated.
By their numbers in this assay, from the lowest: compounds 3 and 4 (each within the scatter of the next); then compound 1; then compound 2.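

In this assay, putting 4-fluorophenyl in place of 3,5-difluorophenyl on the saturated chain carbon gives no change at the digits printed from compound 3 to compound 4 (within the scatter), so the two fluorinated phenyl groups cannot be told apart on this read-out. The one change confined to a single substituent, fluoro in place of nitro on an aromatic carbon, gives a number 24 percentage points lower from compound 1 to compound 4 (beyond the scatter), and the step from the 2-bromophenyl group gives a number 45 percentage points lower from compound 2 to compound 4 (beyond the scatter), so among these four compounds both fluorinated phenyl groups read lower than the 4-nitrophenyl and 2-bromophenyl groups, and none of the four goes against this. No supporting data bear on why this position responds in this way.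

The compounds shown leave open whether the higher reading of compound 2 belongs to bromine itself or to where it sits on the ring, since it is the only compound with either feature. They also leave open how an unsubstituted phenyl, or a phenyl carrying an amine or a carboxylic acid, would read at this position, and how far either fluorinated compound lies from any growth inhibition at all, given a single tested concentration.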